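The source may report more compounds than this note shows. Statements on the series, on what has been measured and on what is new or still open speak of the compounds shown alone.

Compound 1 `COc1cc(-c2cccc3nc(-c4ccccc4)oc23)cc(OC)c1OC` is built around a shared core that carries a trimethoxyphenyl group on one side and a plain phenyl group on the other. In a functional assay on A549 cells (Homo sapiens) for antiproliferative activity, read by MTT assay, with a stated time of 48 h (a lower number here means a stronger inhibitor, a higher number a weaker inhibitor), compound 1 gives 20300 nM, the highest of the three numbers measured. Compound 2 `COc1cccc(-c2nc3cccc(-c4cc(OC)c(OC)c(OC)c4)c3o2)c1` has a methoxy in place of hydrogen on an aromatic carbon of that phenyl; in this assay compound 2 gives 3500 nM, and the step is a 5.8-fold lower number from compound 1 to compound 2 (0.76 log units; beyond the scatter). Compound 3 `COc1cc(-c2nc3cccc(-c4cc(OC)c(OC)c(OC)c4)c3o2)ccc1O` carries 4-hydroxy-3-methoxyphenyl in place of phenyl; in this assay compound 3 gives 15700 nM, which means a 1.3-fold lower number from compound 1 to compound 3 (0.11 log units; within the scatter) and a 4.5-fold higher number from compound 2 to compound 3 (0.65 log units; beyond the scatter).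

Compound 4 `COc1cc(-c2cccc3nc(-c4ccc(N)cc4)oc23)cc(OC)c1OC` differs from compound 1 by amino in place of hydrogen on an aromatic carbon. Among the measured compounds shown here, no measured compound carries an amino group, so the nearest guides are the other small groups placed on the same phenyl: a methoxy entering gave a 5.8-fold lower number from compound 1 to compound 2 (0.76 log units; beyond the scatter), while a hydroxy entering gave a 4.5-fold higher number from compound 2 to compound 3 (0.65 log units; beyond the scatter). These point in opposite directions, so a small step, most likely a lower number but possibly within the scatter, is expected for a 1.7-fold lower number from compound 1 to compound 4 (0.23 log units; within the scatter). In this assay compound 4 is estimated to give 12000 nM, within a range from 4000 nM to 35000 nM.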

Compound 4, half-maximal inhibitory concentration: 720 nM
For compound 4 the middle estimate is 17-fold (1.22 log units) above the measured one; measured number outside the range, below it.
By their numbers in this assay, from the lowest: compound 4; then compound 2; then compounds 3 and 1 (each within the scatter of the next).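

In this assay the change from phenyl to 4-aminophenyl gives a 28-fold lower number from compound 1 to compound 4 (1.45 log units; beyond the scatter) and is larger than any step among the first three compounds, so this one ring can move the number much further than the methoxy and hydroxy changes had shown. The 4-aminophenyl compound also compares well with both earlier substituted rings, with a 4.9-fold lower number from compound 2 to compound 4 (0.69 log units; beyond the scatter) and a 22-fold lower number from compound 3 to compound 4 (1.34 log units; beyond the scatter) making compound 4 the strongest inhibitor of the four, which shows that what sits on this ring matters greatly even though the rest of the molecule stays the same. Nothing available here explains why a single amino group para to a large group has such an effect.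

Still open, on these data alone, is whether the amino group itself is what counts, since a dimethylamino group, an acetamide or a nitro group in the same place would test how much its exact form matters. As far as these compounds go, it is also open whether an amino group elsewhere on this ring, or a lone hydroxy in its place without the neighbouring methoxy, would give a similar number.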